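Nitro to methoxy: working notes on the series

The source may hold more compounds than are shown below. What is called first, only, known or untested is meant among the compounds shown, and "the series" means these compounds.

Measured in a functional assay (aorta) for inhibition, with Rattus norvegicus as the target, with a stated time of 8 days; a higher number here means a weaker inhibitor, a lower number a stronger inhibitor:
- compound 1 `Cc1nsc(-c2ccc(N3CCN(c4cccc(Cl)c4)CC3)nn2)n1`: 0.6 nM
- compound 2 `Cc1nsc(-c2ccc(N3CCN(c4cccc([N+](=O)[O-])c4)CC3)nn2)n1`: 3 nM

Of the two measured compounds, compound 2 has the higher number, 3 nM. Next is compound 3 `COc1cccc(N2CCN(c3ccc(-c4nc(C)ns4)nn3)CC2)c1`, with methoxy in place of nitro on an aromatic carbon. Going by the values given here, only one measured step bears on this, a 5.0-fold higher number from compound 1 to compound 2 (0.70 log units; beyond the scatter), a modest one in which nitro replaced chloro. Among the compounds with values here, no measured compound carries methoxy, so the evidence is thin. A modest step toward a lower number in this assay is expected, of similar size or smaller. The expected step is a 2.0-fold lower number from compound 2 to compound 3 (0.30 log units; within the scatter). The estimate for compound 3 is 1.5 nM, with an expected range of 0.4 nM to 6 nM.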

Compound 3, half-maximal inhibitory concentration: 7 nM
For compound 3 the middle estimate is 4.7-fold (0.67 log units) below the measured one; measured number outside the range, above it.
By their numbers in this assay, from the lowest: compound 1; then compound 2; then compound 3.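

At this place on the aromatic ring, methoxy in place of nitro raises the number in this assay, giving a 2.3-fold higher number from compound 2 to compound 3 (0.37 log units; beyond the scatter), and methoxy in place of chloro gives a 12-fold higher number from compound 1 to compound 3 (1.07 log units; beyond the scatter). The order of the three groups is now chloro, nitro, methoxy from the lowest number, with chloro beyond the scatter from both others. Nothing measured here accounts for this order.

On these data alone, whether an amine or a carboxylic acid at this place would give a number lower than that of chloro remains open. So does whether the same order holds elsewhere on this ring.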